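Removing the Trifluoromethyl Group from Compound 2

The source may hold more compounds than are shown below. What is called first, only, known or untested is meant among the compounds shown, and "the series" means these compounds.

Three compounds have been measured in a functional assay on SN12C cells (Homo sapiens) for inhibition, read by sulforhodamine B assay, with a stated time of 48 h; on this read-out lower numbers stand for stronger inhibition of growth and higher numbers for weaker inhibition of growth:

compound 1, `O=C(Nc1cccc(-n2cc(-c3ccncc3)c(-c3ccc(Cl)c(O)c3)n2)c1)Nc1ccc(Cl)c(Cl)c1`, gives 1310 nM
compound 2, `COc1cc(-c2nn(-c3cccc(NC(=O)c4cccc(C(F)(F)F)c4)c3)cc2-c2ccncc2)ccc1Cl`, gives 3310 nM
compound 3, `O=C(Nc1cccc(-n2cc(-c3ccncc3)c(-c3ccc(Cl)c(O)c3)n2)c1)Nc1cc(C(F)(F)F)cc(C(F)(F)F)c1`, gives 1030 nM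

Among these three, compound 2 stands at the highest number, meaning the weakest inhibition of growth. Compound 1 is the nearest to it, with a lower number, and that gap lies beyond the usual scatter of repeated measurements. Compound 3 lies furthest from compound 2, again with a lower number, and that gap too is beyond the scatter.

Compound 4, `COc1cc(-c2nn(-c3cccc(NC(=O)c4ccccc4)c3)cc2-c2ccncc2)ccc1Cl`, has not yet been measured. It differs from compound 2 in one place: hydrogen in place of trifluoromethyl on an aromatic carbon. Within the data shown here, no pair of measured compounds shows this same change, so there is no direct guide to its effect. The expectation is that the step from compound 2 to compound 4 in this assay is small, possibly a modest rise in the number, and may well fall within the scatter; the expected step is a 1.4-fold higher number from compound 2 to compound 4 (0.13 log units; within the scatter). Compound 4 is therefore estimated to give 4500 nM in this assay, with a range from 1500 nM to 13000 nM.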

Compound 4, concentration for 50% growth inhibition: 2950 nM
The estimate for compound 4 lay 1.5-fold (0.18 log units) above the measured number, and the stated range covers the measured number.
By their numbers in this assay, from the lowest: compounds 3 and 1 (each within the scatter of the next); then compounds 4 and 2 (each within the scatter of the next).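

Putting hydrogen in place of trifluoromethyl on this aromatic carbon gives a 1.1-fold lower number from compound 2 to compound 4 (0.05 log units; within the scatter) in this assay and so leaves growth inhibition unchanged within the scatter. Among these compounds, this is the first reading of this change, since no earlier pair carried it, and it shows that the 3-(trifluoromethyl)phenyl can give way to a plain phenyl with no readable loss. Nothing measured here speaks to why the step is so small.

On these data alone, it remains open how an amine or a carboxylic acid on this same aromatic carbon would compare with hydrogen and trifluoromethyl. As far as these compounds go, it also remains open whether this change would give an equally small step in a compound with a different core or a different linking group.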